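Swapping Nitro for Diethylamino at an Unreadable Limit

The compounds below may be only part of what the source reports. "The series", "measured", "known", "first", "only" and "open" are said of these compounds alone.

Compound 2 `COc1ccc(/C=C/c2ccc3ccccc3c2)cc1[N+](=O)[O-]` has no exact number in a functional assay on HCT-116 cells (Homo sapiens) for inhibition; a higher number here means a weaker inhibitor, a lower number a stronger inhibitor. Compound 2 reads > 5000 nM, which is a limit of the assay and not a measured value. Compound 1 `COc1ccc(/C=C/c2ccc3ccccc3c2)cc1` reads > 5000 nM, also a limit. Compound 3 `COc1ccc(/C=C\c2ccc3ccccc3c2)cc1[N+](=O)[O-]` reads > 20000 nM, again a limit.

Compound 4 `CCN(CC)c1cc(/C=C/c2ccc3ccccc3c2)ccc1OC` keeps the core of compound 2 and changes one group: diethylamino in place of nitro on an aromatic carbon. In words, diethylamino takes the place of nitro on an aromatic carbon, ortho to a methoxy group.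

Among the compounds with values here, two measured steps bear on this change. Putting nitro in place of hydrogen gave a step that the two limits leave unreadable from compound 1 to compound 2. Turning the double bond from E to Z gave a step that the two limits leave unreadable from compound 2 to compound 3, and the fact that compounds 2 and 3 differ only in the configuration as drawn is the whole structural difference there. Within the data shown here, neither step has a readable size, and no compound so far has a value for diethylamino to be compared with.

The starting point therefore remains compound 2 at > 5000 nM, a limit, and another limit is the likeliest report. The estimated step that the limit leaves unreadable from compound 2 to compound 4 is none beyond the scatter, in either direction. Compound 4 is expected to come in at about 7000 nM, with an estimated range from 2000 nM to 30000 nM.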

Compound 4, half-maximal inhibitory concentration: > 5000 nM
Compound 4 gave a limit, no number; the forecaster's own chance of this, stated with the estimate: 65%; the middle value is on the limit's open side.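

In this assay compound 4 reads > 5000 nM, a limit of the assay and not a number. Compound 1 and compound 2 also stand at limits, and the steps from each of them to compound 4 cannot be read. The compounds shown leave open whether hydrogen, nitro or diethylamino at this place changes inhibition at all.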